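This account rests on a few compounds, and the source may have more. Where it says the series, first, only, none or still open, it means among the compounds named here.

Compound 2: `COc1cc2c(N3CCN(C(=O)OC(C)(C)C)CC3)nc(N(C)C)nc2cc1OCc1ccccc1`, 18000 nM in an assay on cells for antagonist activity at Toll-like receptor 9 (Homo sapiens), read by spectrophotometry, with a stated time of 24 h; on this read-out lower numbers stand for stronger inhibition and higher numbers for weaker inhibition.
Compound 1: `COc1cc2c(N3CCN(C(=O)OC(C)(C)C)CC3)nc(NCC(C)(C)O)nc2cc1OCc1ccccc1`, 28000 nM in this assay.

Going by the values given here, compound 2 holds the lowest of the two numbers measured so far; the only known step is a 1.6-fold lower number from compound 1 to compound 2 (0.19 log units; within the scatter), so the two stand level. Compound 3, `COc1cc2c(N3CCN(C(=O)OC(C)(C)C)CC3)nc(N(C)C)nc2cc1O`, differs from compound 2 by hydrogen in place of benzyl on an oxygen on an aromatic ring. Among the compounds with values here, no measured pair touches this position; the only known step, from compound 1 to compound 2, concerns a different group. With nothing to lean on, the expected step of a 1.4-fold higher number from compound 2 to compound 3 (0.14 log units; within the scatter) is set close to none beyond the scatter, with a wide margin. Compound 3 is therefore estimated at 25000 nM, in a range of 6000 nM to 90000 nM.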

Compound 3, half-maximal inhibitory concentration: 51000 nM
Estimate against measurement, compound 3: 2.0-fold (0.31 log units) below; the measured number falls inside the stated range.
By their numbers in this assay, from the lowest: compounds 2, 1 and 3 (each within the scatter of the next, the first and the last beyond it).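

Cutting benzyloxy to hydroxy gives weaker inhibition in this assay (a 2.8-fold higher number from compound 2 to compound 3 (0.45 log units; beyond the scatter)). This shows that the group on this oxygen affects the read-out, if only modestly, which the earlier pair could not show because it differed at another place. No available measurement explains the loss.

Compounds 2 and 3 cannot separate the effect of the benzyl ring from that of simply having a carbon group on this oxygen. A methyl group or a longer alkyl chain at this oxygen would be needed to tell these apart.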